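Propyl on the acetamide side of compound 3

The source may hold more compounds than are shown below. What is called first, only, known or untested is meant among the compounds shown, and "the series" means these compounds.

Measured so far in a physicochemical assay for lipophilicity; a lower number here means a more polar compound, a higher number a more lipophilic compound:
- compound 1 `CC(C)c1nc2ccccc2[nH]1` gives 2.41 here
- compound 2 `CCCCCCCc1nc2ccccc2[nH]1` gives 4.43 here
- compound 3 `CC(=O)Nc1ccc2[nH]c(C)nc2c1` gives 0.61 here

In this assay compound 3 holds the lowest of the three numbers. Its nearest neighbour is compound 1 (2.41) and its furthest is compound 2 (4.43), and both gaps lie beyond the scatter.

The next compound to be measured is compound 4 `CCCCC(=O)Nc1ccc2[nH]c(C)nc2c1`, which departs from compound 3 in one place: propyl in place of hydrogen on a saturated chain carbon bound to a carbonyl carbon. The same difference, cut one bond further out, reads methyl to butyl.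

For the measured compounds named here, no measured pair isolates this change, so the size of the step cannot be read from the data. The expectation rests on the structural change alone, and on the span of the three numbers, from compound 3 (0.61) to compound 2 (4.43).

A rise beyond the scatter is expected, estimated as a number 1.44 log units higher from compound 3 to compound 4 (beyond the scatter), in this assay.

For compound 4 the estimated value is 2.05, with an expected range from 1.5 to 2.6.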

Compound 4, partition coefficient: 2.11
The estimate for compound 4 lay 0.06 log units below the measured number; the range from low to high includes it.
By their numbers in this assay, from the lowest: compound 3; then compounds 4 and 1 (each within the scatter of the next); then compound 2.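

In this assay, for the compounds shown here, the change reads a number 1.50 log units higher from compound 3 to compound 4 (beyond the scatter) and is the first step that isolates one place, since compounds 1, 2 and 3 offered no such pair. It gives a first size for this position: propyl in place of hydrogen on a saturated chain carbon bound to a carbonyl carbon, a difference that also reads as methyl to butyl, moves the number by a large step while the rest of compound 3 stays unchanged. This size rests on a single pair, and nothing measured on the series bears on why the step is this large.

One step cannot show whether the number follows chain length at this carbon, so an ethyl group or a longer chain such as hexyl in the same place would be needed to tell a steady climb from a levelling off. Going by these compounds, it also remains open how an amine, a carboxylic acid or a small ring such as cyclopropyl on this carbon would compare with propyl, and whether the step would keep its size on another core.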